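Notes on carbonyl substituent variation and Caco-2 permeability

The source may report more compounds than this note shows. Statements on the series, on what has been measured and on what is new or still open speak of the compounds shown alone.

Values in an ADME assay on Caco-2 cells (Homo sapiens) for permeability, in the apical to basolateral direction; on this read-out lower numbers stand for lower permeability and higher numbers for higher permeability:
compound 1 `C=C(C)C(=O)N1CCC(CN(C2Cc3cc(C#N)ccc3N(Cc3cncn3C)C2)S(=O)(=O)c2ccccn2)CC1` gives 0.5 10^-6 cm/s
compound 2 `Cn1cncc1CN1CC(N(CC2CCN(C(=O)NC(C)(C)C)CC2)S(=O)(=O)c2ccccn2)Cc2cc(C#N)ccc21` gives 0.6 10^-6 cm/s
compound 3 `CC(=O)N1CCC(CN(C2Cc3cc(C#N)ccc3N(Cc3cncn3C)C2)S(=O)(=O)c2ccccn2)CC1` gives 0.5 10^-6 cm/s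

Compound 2 sits within the scatter of both others: a 1.2-fold higher number from compound 1 to compound 2 (0.08 log units; within the scatter) and a 1.2-fold lower number from compound 2 to compound 3 (0.08 log units; within the scatter); likewise no change at the digits printed from compound 1 to compound 3 (within the scatter). None of the three steps moves the read-out beyond the scatter, so the three measured compounds give no separation in this assay.

Compound 4 `Cn1cncc1CN1CC(N(CC2CCN(C(=O)c3ccccc3)CC2)S(=O)(=O)c2ccccn2)Cc2cc(C#N)ccc21` differs from compound 2 by phenyl in place of (tert-butyl)amino on a carbonyl carbon. The three measured steps all sit on the same carbonyl carbon and all stayed within the scatter, and none of them introduces a phenyl, so they bear on the change only weakly. No step beyond the scatter is therefore expected: no change at the digits printed from compound 2 to compound 4 (within the scatter) is the estimated step. For compound 4 the expected value is 0.6 10^-6 cm/s, with a range of 0.3 10^-6 cm/s to 1.2 10^-6 cm/s.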

Compound 4, apparent permeability: 0.5 10^-6 cm/s
Estimate against measurement, compound 4: 1.2-fold (0.08 log units) above; measured number inside the range.
By their numbers in this assay, from the lowest: compounds 1, 3, 4 and 2 (each within the scatter of the next).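

In this assay, a phenyl on this carbonyl carbon, the first aromatic ring there, reads within the scatter against (tert-butyl)amino (a 1.2-fold lower number from compound 2 to compound 4 (0.08 log units; within the scatter)), methyl (no change at the digits printed from compound 3 to compound 4 (within the scatter)) and 1-methylethenyl (no change at the digits printed from compound 1 to compound 4 (within the scatter)). Across these four compounds, neither the ring entering nor the hydrogen-bond donor of (tert-butyl)amino leaving separates the read-out at this position. No measurement at hand explains this flat result.

Going by these compounds, whether a carboxylic acid or an aminoalkyl chain on this carbonyl carbon would move the number beyond the scatter stays open. On these data alone, the effect of any change elsewhere on the shared core also stays open.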